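This account rests on a few compounds, and the source may have more. Where it says the series, first, only, none or still open, it means among the compounds named here.

Measured compounds:
compound 1, `CC(C)C(=O)OCOC(=O)C1=C(S[C@@H]2CN[C@H](C(=O)Nc3cccc(C(=O)O)c3)C2)[C@H](C)[C@@H]2[C@@H]([C@@H](C)O)C(=O)N12`, 0%
compound 2, `CC(C)C(=O)OCOC(=O)C1=C(S[C@@H]2CN[C@H](C(=O)Nc3cccc(C(=O)OCOC(=O)C(C)C)c3)C2)[C@H](C)[C@@H]2[C@@H]([C@@H](C)O)C(=O)N12`, 1%
compound 3, `Cc1oc(=O)oc1COC(=O)N1C[C@@H]2C[C@H]1C(=O)Nc1cccc(c1)C(=O)OC/C=C\COC(=O)C1=C(S2)[C@H](C)[C@@H]2[C@@H]([C@@H](C)O)C(=O)N12`, 0%

In an ADME assay on a cell-free system (plasma, Rattus norvegicus) for metabolic stability, read by LC-MS, with a stated time of 60 min, at 37 degrees C, tested at 50 uM (on this read-out higher numbers stand for a more stable compound and lower numbers for a less stable compound), compound 1 gives 0%. On this read-out compound 1 stands level with compound 3 at the digits shown, and the two together are the lowest of the three numbers; compound 2 is the furthest from compound 1, and the step of a number 1 percentage points higher from compound 1 to compound 2 (within the scatter) lies within the scatter, so all three measured compounds sit at the floor of the read-out with no separation between them.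

Compound 4, `C[C@@H](O)[C@H]1C(=O)N2C(C(=O)OCC(F)(F)F)=C(S[C@@H]3CN[C@H](C(=O)Nc4cccc(C(=O)O)c4)C3)[C@H](C)[C@H]12`, has not yet been measured. It differs from compound 1 as follows: trifluoromethyl in place of (isopropylcarbonyl)oxy on a saturated chain carbon bound to an oxygen next to a carbonyl group. Among the measured compounds shown here, the only measured step, from compound 1 to compound 2, adds ((isopropylcarbonyl)oxy)methyl on an oxygen next to a carbonyl group and leaves the read-out unchanged within the scatter; no measured pair changes the group that is exchanged here, so the data give no direct guide for its size or direction.

With every measured compound at the floor of this assay, compound 4 is expected to stay near that floor, with an estimate of 5%, in a range from 0% to 40%. The step of a number 5 percentage points higher from compound 1 to compound 4 (within the scatter) is therefore expected to be small, though the range is wide because nothing measured here tests this exchange.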

Compound 4, percent of the compound remaining: 7%
For compound 4 the middle estimate is 2 percentage points below the measured one, and the stated range covers the measured number.
By their numbers in this assay, from the lowest: compounds 1, 3, 2 and 4 (each within the scatter of the next).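

Replacing (isopropylcarbonyl)oxy with trifluoromethyl on a saturated chain carbon bound to an oxygen next to a carbonyl group gives, in this assay, a number 7 percentage points higher from compound 1 to compound 4 (within the scatter) and so does not separate the two compounds. The earlier compounds shown here showed no exchange at this place, and this one shows that the (isopropylcarbonyl)oxy group can be replaced by a trifluoromethyl group that shares none of its oxygen atoms without a change beyond the scatter. Nothing shown here offers a reason for this reading.

Going by these compounds, it remains open whether a plain ethyl group, a longer chain or a chain ending in an amine at this place would give a number clear of the scatter. On these data alone, it also remains open whether the same exchange would read alike with the shared core carrying a second ester, as in compound 2.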